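Methyl on the Sulfonamide Nitrogen: An Expected Small Step

The source may hold more compounds than are shown below. What is called first, only, known or untested is meant among the compounds shown, and "the series" means these compounds.

Of the compounds shown here, two have been measured in an assay on SK-BR-3 cells for inhibition of Aromatase (Homo sapiens); on this read-out higher numbers stand for weaker inhibition and lower numbers for stronger inhibition. Compound 1 `COc1ccc(COc2cc([N+](=O)[O-])ccc2N(C)S(C)(=O)=O)cc1` gives 470 nM in this assay. Compound 2 `CS(=O)(=O)Nc1ccc([N+](=O)[O-])cc1OCc1ccc(-c2ccccc2)cc1` gives 850 nM in this assay. The two numbers sit within the usual scatter of each other, so on this evidence compound 2 and compound 1 cannot be told apart.

Compound 3 `CN(c1ccc([N+](=O)[O-])cc1OCc1ccc(-c2ccccc2)cc1)S(C)(=O)=O` has not yet been measured. It differs from compound 2 in one place: methyl in place of hydrogen on a sulfonamide nitrogen. For the measured compounds named here, no measured pair in this set shows the effect of that single change on its own, since compound 1 also differs from compound 2 at the benzyl ether.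

On this basis the step from compound 2 to compound 3 is expected to be small, a 1.4-fold lower number from compound 2 to compound 3 (0.15 log units; within the scatter), with no clear direction beyond the scatter. Compound 3 is therefore estimated at 600 nM in this assay, within a range from 200 nM to 1800 nM.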

Compound 3, half-maximal inhibitory concentration: 650 nM
Compound 3: the middle estimate sits 1.1-fold (0.03 log units) below what was measured; low and high end bracket the measured number.
By their numbers in this assay, from the lowest: compounds 1, 3 and 2 (each within the scatter of the next).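

In this assay, for the compounds shown here, methyl in place of hydrogen on the sulfonamide nitrogen gives a 1.3-fold lower number from compound 2 to compound 3 (0.12 log units; within the scatter), the first direct reading of this single change, and it shows that compound 2 and compound 3 cannot be told apart. Phenyl in place of methoxy on an aromatic carbon gives a 1.4-fold higher number from compound 1 to compound 3 (0.14 log units; within the scatter), so with methyl on the sulfonamide nitrogen this swap cannot be told from the scatter either. Nothing available explains why these numbers stay so close.

As far as these compounds go, whether a longer chain such as propyl on the sulfonamide nitrogen would also leave the number within the scatter remains open. So does the outcome of putting an amine or a carboxylic acid in place of the phenyl.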